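This account rests on a few compounds, and the source may have more. Where it says the series, first, only, none or still open, it means among the compounds named here.

Compound 2, `Cc1ccc(/C=N/NC(=O)c2ccc(O[C@@H]3O[C@H](CO)[C@@H](O)[C@H](O)[C@H]3O)cc2)cc1`, is the reference point here. Among the measured compounds shown here, in a functional assay on MDA-MB-231 cells (Homo sapiens) for inhibition, read by MTT assay, with a stated time of 24 h, tested at 100 uM (a higher number here means more inhibition at the concentration tested (going by the name of the read-out), a lower number less inhibition), compound 2 gives 9.28%, the highest of the two numbers so far, with compound 1, `O=C(N/N=C/c1cccc([N+](=O)[O-])c1)c1ccc(O[C@@H]2O[C@H](CO)[C@@H](O)[C@H](O)[C@H]2O)cc1`, nearest: in this assay compound 1 gives 6.23%. For the measured compounds named here, the single measured step, a number 3.1 percentage points higher from compound 1 to compound 2 (within the scatter), lies within the scatter, so the two compounds cannot be ordered.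

Compound 3 is `O=C(N/N=C/c1ccccc1)c1ccc(O[C@@H]2O[C@H](CO)[C@@H](O)[C@H](O)[C@H]2O)cc1`. Its structural change from compound 2 is hydrogen in place of methyl on an aromatic carbon. Going by the values given here, no measured step concerns this change directly; the one measured step, a number 3.1 percentage points higher from compound 1 to compound 2 (within the scatter), concerns a different aryl exchange on the same carbon and moved the read-out hardly at all. Both measured values sit near the bottom of the scale, and the change to compound 3 is smaller than the one already measured. The expectation for compound 3 is therefore a step of a number 2.3 percentage points lower from compound 2 to compound 3 (within the scatter), no movement beyond the scatter. On that basis compound 3 is estimated to give 7% in this assay, within a range from 0% to 18%.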

Compound 3, a percentage reported as inhibition, at one concentration (the size of the read-out at that concentration, not a potency): 3.56%
For compound 3 the middle estimate is 3.4 percentage points above the measured one; measured number inside the range.
By their numbers in this assay, from the lowest: compounds 3, 1 and 2 (each within the scatter of the next).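

Compound 3 carries no substituent on this aryl ring, so it gives the position a baseline that the earlier pair lacked. In this assay, replacing methyl with hydrogen gives a step of a number 5.7 percentage points lower from compound 2 to compound 3 (within the scatter), and replacing nitro with hydrogen gives a step of a number 2.7 percentage points lower from compound 1 to compound 3 (within the scatter). The 4-methylphenyl, 3-nitrophenyl and phenyl compounds therefore cannot be told apart here, and neither methyl nor nitro shows any measurable difference from hydrogen on this ring, while no information is available on why the numbers for these three compounds take the values they do.

On these data alone, it remains open whether an amine or a carboxylic acid on this ring, or a longer chain in place of the methyl para to the large group, would give a number that separates from these three beyond the scatter. All three compounds share the rest of the core, so they say nothing about changes elsewhere in it, and a single-concentration percentage does not provide a potency for any of them.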